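Swapping the sulfur-linked side chain of compound 3 for an acetamidoethyl group

This account rests on a few compounds, and the source may have more. Where it says the series, first, only, none or still open, it means among the compounds named here.

Of the compounds shown here, three sharing the same core have been measured in a functional assay on HT cells (Homo sapiens) for antiproliferative activity, read by fluorescence, with a stated time of 72 h; on this read-out higher numbers stand for weaker inhibition of growth and lower numbers for stronger inhibition of growth. Compound 3 `CCC(CO)Sc1nc(NCc2ccc(-c3ccccn3)cc2)c2[nH]nc(C(C)C)c2n1` gives 255 nM, the highest number of the three. Compound 1 `CC(C)c1n[nH]c2c(NCc3ccc(-c4ccccn4)cc3)nc(SCCCN)nc12` gives 120 nM, and compound 2 `CC(C)c1n[nH]c2c(NCc3ccc(-c4ccccn4)cc3)nc(SCC(C)(C)N)nc12` gives 85 nM; the step of a 1.4-fold lower number from compound 1 to compound 2 (0.15 log units; within the scatter) is small, while a 2.1-fold higher number from compound 1 to compound 3 (0.33 log units; beyond the scatter) and a 3.0-fold higher number from compound 2 to compound 3 (0.48 log units; beyond the scatter) are modest. Compound 4 `CC(=O)NCCSc1nc(NCc2ccc(-c3ccccn3)cc2)c2[nH]nc(C(C)C)c2n1` differs from compound 3 only on the sulfur: 2-acetamidoethyl in place of 1-(hydroxymethyl)propyl on a sulfur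

The two steps that bear on the change are those into compound 3, in which a 3-aminopropyl or a 2-amino-2-methylpropyl group was replaced by 1-(hydroxymethyl)propyl on the sulfur and the number rose modestly. Compound 4 keeps a group with one hydrogen-bond donor and one acceptor and no net charge, as in compound 3, so the author expects no step beyond the scatter, with a slight lean to a higher number. Compound 4 is therefore estimated at 300 nM in this assay, within 120 nM to 750 nM, which means an expected step of a 1.2-fold higher number from compound 3 to compound 4 (0.07 log units; within the scatter).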

Compound 4, concentration for 50% growth inhibition: 71 nM
Estimate against measurement, compound 4: 4.2-fold (0.63 log units) above; measured number outside the range, below it.
By their numbers in this assay, from the lowest: compounds 4, 2 and 1 (each within the scatter of the next); then compound 3.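

Moving from 1-(hydroxymethyl)propyl to 2-acetamidoethyl on this sulfur gives a 3.6-fold lower number from compound 3 to compound 4 (0.56 log units; beyond the scatter) in this assay, although both groups have the same counts of hydrogen-bond donors and acceptors and no net charge, so those counts alone do not set the number at this position. Compound 4 carries no free amino group, yet the comparisons with the amino chains give a 1.2-fold lower number from compound 2 to compound 4 (0.08 log units; within the scatter) and a 1.7-fold lower number from compound 1 to compound 4 (0.23 log units; within the scatter), which places these three compounds together and leaves compound 3 apart. Nothing measured here explains the difference between the two uncharged groups.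

The two groups differ both in the acetamido function and in chain branching, and the compounds shown do not separate these. A 2-hydroxyethyl group or a longer chain ending in acetamido on the sulfur would bear on that question.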